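Working notes: chloro-to-nitro step applied a second time

The source may report more compounds than this note shows. Statements on the series, on what has been measured and on what is new or still open speak of the compounds shown alone.

Measured so far:
compound 1 `Cc1ccc(C(=O)CCc2nnc(-c3ccc(Cl)cc3)o2)cc1` — in a functional assay on the whole organism (strain Wistar) for inhibition, with Rattus norvegicus as the target, with stated times of 30 min and 2 h, at a dose of 20 mg/kg by the oral route (a lower number here means less inhibition, a higher number more inhibition at the dose given (going by the name of the read-out)), compound 1 gives 62.7%
compound 2 `Cc1ccc(C(=O)CCc2nnc(-c3ccc([N+](=O)[O-])cc3)o2)cc1` — in this assay compound 2 gives 52%
compound 3 `Cc1ccc(C(=O)CCc2nnc(-c3ccc(Cl)cc3)o2)c(C)c1` — in this assay compound 3 gives 53.3%

Two single changes connect the measured compounds. From compound 1 to compound 2 the change is nitro in place of chloro on an aromatic carbon, and the step it made is a number 10.7 percentage points lower from compound 1 to compound 2 (beyond the scatter). From compound 1 to compound 3 the two cores differ by methyl in place of hydrogen on an aromatic carbon, with a step of a number 9.4 percentage points lower from compound 1 to compound 3 (within the scatter). Compound 2 and compound 3 are not linked by a single change; their two numbers lie close together.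

Compound 4 `Cc1ccc(C(=O)CCc2nnc(-c3ccc([N+](=O)[O-])cc3)o2)c(C)c1` is not yet measured. It differs from compound 3 by nitro in place of chloro on an aromatic carbon. Going by the values given here, this is the same change, at the same kind of place, as the one from compound 1 to compound 2; the place is described in the same words for both pairs.

Among the compounds with values here, the expectation for compound 4 rests on the one earlier instance of this change, the step of a number 10.7 percentage points lower from compound 1 to compound 2 (beyond the scatter), carried over to the core of compound 3. Within the data shown here, a step of about the same size and direction is expected from compound 3 to compound 4, a number 10.3 percentage points lower from compound 3 to compound 4 (beyond the scatter), with a wide range because only one prior example of the change exists. Compound 4 is estimated at 43%, between 30% and 56%.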

Compound 4, a percentage reported as inhibition, in the whole organism at one dose (the size of the read-out at that dose, not a potency): 40%
Compound 4: the middle estimate sits 3 percentage points above what was measured; the measured number falls inside the stated range.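

In this assay, nitro in place of chloro on an aromatic carbon, para to a large group, gives a step on the core of compound 3 that matches the earlier step on the core of compound 1, a number 13.3 percentage points lower from compound 3 to compound 4 (beyond the scatter): the same change on two cores in this assay, a number 10.7 percentage points lower (beyond the scatter) from compound 1 to compound 2 and a number 13.3 percentage points lower (beyond the scatter) from compound 3 to compound 4, 2.6 percentage points apart, within the scatter of two such steps. The methyl change also carries over from the chloro compounds to the nitro compounds, a number 12 percentage points lower from compound 2 to compound 4 (beyond the scatter): the same change on two cores in this assay, a number 9.4 percentage points lower (within the scatter) from compound 1 to compound 3 and a number 12 percentage points lower (beyond the scatter) from compound 2 to compound 4, 2.6 percentage points apart, within the scatter of two such steps. These two comparisons come from the same four compounds, so they are one agreement seen from two sides; they support treating the two changes as carrying over on these two cores, but they do not show that this holds on any other core, and they say nothing about why the numbers fall.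

On these data alone, it remains open whether an amine, a carboxylic acid or a nitrile in place of chloro would fit the same picture, and whether the methyl step would hold on a core with a longer chain in place of the one bearing the carbonyl. All the numbers are also read at a single dose, so they give the size of the inhibition at that dose and leave potency open.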